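Cyclohexyl for Methyl: Expecting the Next Result

The source may hold more compounds than are shown below. What is called first, only, known or untested is meant among the compounds shown, and "the series" means these compounds.

Compound 1 `COC(=O)c1nc(C)n(-c2ccccc2)n1`: in a functional assay on NPC-TW01 cells (Homo sapiens) for inhibition, read by MTT assay, with a stated time of 72 h (on this read-out higher numbers stand for weaker inhibition of growth and lower numbers for stronger inhibition of growth), compound 1 gives > 100000 nM, which is a limit of the assay, not a number.
Compound 2 `COC(=O)c1nc(C)n(-c2ccc(C(F)(F)F)cc2)n1`: in this assay compound 2 gives > 100000 nM, again a limit rather than a number.
Compound 3 `COC(=O)c1nc(C)n(-c2ccc(Cl)cc2)n1`: in this assay compound 3 gives 17500 nM.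

Compound 2 therefore stands at the assay limit, without a measured number. the limit of > 100000 nM in this assay, at which 2 of the 3 values shown sit, is where two of the three values sit. Compound 4 `COC(=O)c1nc(C2CCCCC2)n(-c2ccc(C(F)(F)F)cc2)n1` differs from compound 2 by cyclohexyl in place of methyl on an aromatic carbon. The measured steps, a step that the two limits leave unreadable from compound 1 to compound 2, an at least 5.7-fold lower number from compound 1 to compound 3 (0.75 log units; beyond the scatter) and an at least 5.7-fold lower number from compound 2 to compound 3 (0.75 log units; beyond the scatter), all alter the group on the phenyl ring, so none bears on this change. For the measured compounds named here, with no step to lean on, compound 4 is expected to stay weak, an at least 1.2-fold lower number from compound 2 to compound 4 (0.09 log units; that floor lies within the scatter). Compound 4 is estimated at 80000 nM, between 20000 nM and 300000 nM.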

Compound 4, concentration for 50% growth inhibition: > 100000 nM
Compound 4 gave a limit, no number; the forecaster's own chance of this, stated with the estimate: 60%; at least 1.2-fold (0.09 log units) between middle value and limit.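

For the compounds shown here, compound 2 and compound 4 both sit at a limit of the assay, not at a number, so no step between them can be read: the limit of > 100000 nM in this assay, at which 3 of the 4 values shown sit. As far as these compounds go, whether cyclohexyl in place of methyl changes growth inhibition at all stays open.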